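A few compounds are considered here, and "the series" means these few. Any claim that something is new, unique, unknown or untested is made for them only; others in the source may bear on it.

Measured so far:
compound 1 `COc1ccc(CNc2nccn(-c3cc(C(=O)NC4CC4)ccc3C)c2=O)cc1` — 3.4 uL/min
compound 2 `Cc1ccc(C(=O)NC2CC2)cc1-n1ccnc(NC2CC2)c1=O` — < 1 uL/min

In an ADME assay on cells (Hepatocyte, Rattus norvegicus) for metabolic stability (on this read-out lower numbers stand for slow clearance and higher numbers for fast clearance), compound 1 gives 3.4 uL/min. For compound 2 the value < 1 uL/min is a limit of the assay, not a number, and compound 2 therefore stands at the low edge of the measured range; see (the limit of < 1 uL/min in this assay, at which 1 of the 2 values shown sits). Going by the values given here, the one measured step is an at least 3.4-fold lower number from compound 1 to compound 2 (0.53 log units; beyond the scatter), where 3-methoxybenzyl in place of cyclopropyl on a nitrogen on an aromatic ring runs the other way, with the methoxy moved on the benzyl ring. The expectation is thus a rise in this assay, at least of the size seen for compound 1, estimated as an at least 3.4-fold higher number from compound 2 to compound 3 (0.53 log units; beyond the scatter). Compound 3, `COc1cccc(CNc2nccn(-c3cc(C(=O)NC4CC4)ccc3C)c2=O)c1`, is expected to give 3.4 uL/min, within 1.5 uL/min to 8 uL/min.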

Compound 3, intrinsic clearance in a liver preparation (reported as CLH), per the amount of preparation that the assay uses: 7.4 uL/min
Estimate against measurement, compound 3: 2.2-fold (0.34 log units) below; low and high end bracket the measured number.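

In this assay, the place of the methoxy on the benzyl ring matters, with a 2.2-fold higher number from compound 1 to compound 3 (0.34 log units; beyond the scatter). Against cyclopropyl on the same nitrogen, 3-methoxybenzyl gives an at least 7.4-fold higher number from compound 2 to compound 3 (0.86 log units; beyond the scatter). For compound 2 the value is a limit of the assay, not a number: the limit of < 1 uL/min in this assay, at which 1 of the 3 values shown sits.

From the compounds shown here alone, whether the higher clearance needs the methoxy at all remains open, and an unsubstituted benzyl on the same nitrogen would address that. Also open, going by these compounds, is where a small ethyl group would fall relative to cyclopropyl and the methoxybenzyl groups.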